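Notes on compound 4: amide-nitrogen substitution in the series

The source may hold more compounds than are shown below. What is called first, only, known or untested is meant among the compounds shown, and "the series" means these compounds.

Three analogues sharing one core have been measured in a functional assay on HepG2 cells (Homo sapiens) for antiproliferative activity, read by MTT assay, with a stated time of 48 h; a higher number here means a weaker inhibitor, a lower number a stronger inhibitor. Compound 1 `COc1cc(-c2nnc(SCC(=O)c3cccc(Br)c3)n2N)cc(OC)c1OC` gives 56000 nM, compound 2 `COc1cc(-c2nnc(SCC(=O)c3ccccc3F)n2N)cc(OC)c1OC` gives 22600 nM, and compound 3 `COc1cc(-c2nnc(SCC(=O)Nc3ccccc3)n2N)cc(OC)c1OC` gives 49900 nM. Among the single-point steps, a 2.5-fold lower number from compound 1 to compound 2 (0.39 log units; beyond the scatter), a 2.2-fold higher number from compound 2 to compound 3 (0.34 log units; beyond the scatter) and a 1.1-fold lower number from compound 1 to compound 3 (0.05 log units; within the scatter). Compound 3 thus holds the second highest of the three numbers, indistinguishable from compound 1 and separated from compound 2 by a modest margin.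

Compound 4 `COc1ccc(CNC(=O)CSc2nnc(-c3cc(OC)c(OC)c(OC)c3)n2N)cc1OC` differs from compound 3 in one place: 3,4-dimethoxybenzyl in place of phenyl on an amide-type nitrogen. Going by the values given here, no measured step touches the amide-type nitrogen; every step so far exchanges the group on the carbonyl carbon, and none of those moved the number by more than a modest amount. On that basis the expected step in this assay is a 1.2-fold lower number from compound 3 to compound 4 (0.10 log units; within the scatter), with no change beyond the scatter anticipated in either direction. Compound 4 is therefore estimated at 40000 nM, with a range from 15000 nM to 110000 nM.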

Compound 4, half-maximal inhibitory concentration: > 100000 nM
Compound 4: a limit, no number; the forecaster's own chance of this, stated with the estimate: 10%; middle value at least 2.5-fold (0.39 log units) away from the limit.
By their numbers in this assay, from the lowest: compound 2; then compounds 3 and 1 (each within the scatter of the next). At a limit, above all of these: compound 4.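

In this assay, going by these compounds alone, compound 4 gives a limit and no number, the first reading at the amide-type nitrogen: the limit of > 100000 nM in this assay, at which 1 of the 4 values shown sits. The step is an at least 2.0-fold higher number from compound 3 to compound 4 (0.30 log units; that floor lies within the scatter), so 3,4-dimethoxybenzyl in place of phenyl at this position gave no lower number, while the true size of the rise stays unresolved. The earlier steps shown here all exchanged the group on the carbonyl carbon and gave no reading of this nitrogen, which now shows a change whose outcome cannot be placed on the scale of those steps.

On these data alone, it remains open whether this outcome goes with the benzyl carbon or with the methoxy groups, which an unsubstituted benzyl group on the same nitrogen would separate. Also open, as far as these compounds go, is how a basic amine, such as a dimethylaminoethyl chain, would read at this position.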